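The source may hold more compounds than are shown below. What is called first, only, known or untested is meant among the compounds shown, and "the series" means these compounds.

Compound 1, `O=c1oc2ccccc2cc1C1=NN(c2ccccc2)[C@@H](c2ccccc2)C1`, gives 27.2% in a functional assay on the whole organism (strain albino) for inhibition, with Rattus norvegicus as the target, read by paw edema, with stated times of 1 h and 2 h, at a dose of 200 mg/kg by the oral route; a higher number here means more inhibition at the dose given (going by the name of the read-out), a lower number less inhibition.
Compound 2, `COc1ccc([C@H]2CC(c3cc4ccccc4oc3=O)=NN2c2ccccc2)cc1`, gives 24.8%.
Compound 3, `CN(C)c1ccc([C@H]2CC(c3cc4ccccc4oc3=O)=NN2c2ccccc2)cc1`, gives 28.4%.

Compound 3 holds the highest of the three numbers shown, yet neither gap sets it apart: the step of a number 1.2 percentage points higher from compound 1 to compound 3 (within the scatter) and the step of a number 3.6 percentage points higher from compound 2 to compound 3 (within the scatter) both lie within the scatter, as does the step of a number 2.4 percentage points lower from compound 1 to compound 2 (within the scatter). On these numbers the three compounds cannot be ordered.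

The next compound, compound 4, `O=c1oc2ccccc2cc1C1=NN(c2ccccc2)[C@@H](c2cccc([N+](=O)[O-])c2)C1`, differs from compound 3 in one place: 3-nitrophenyl in place of 4-(dimethylamino)phenyl on a saturated ring carbon. Going by the values given here, the steps that bear on this change are the two that already vary the group on the saturated ring carbon, a number 1.2 percentage points higher from compound 1 to compound 3 (within the scatter) and a number 3.6 percentage points higher from compound 2 to compound 3 (within the scatter), and both are within the scatter. Among the compounds with values here, no measured step places a nitro group, so there is no ground to expect anything beyond the scatter here either. The step of a number 1.4 percentage points lower from compound 3 to compound 4 (within the scatter) is therefore expected to be small, in no settled direction. Compound 4 is estimated at 27%, within a range from 18% to 36%.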

Compound 4, a percentage reported as inhibition, in the whole organism at one dose (the size of the read-out at that dose, not a potency): 26.1%
For compound 4 the middle estimate is 0.9 percentage points above the measured one; low and high end bracket the measured number.
By their numbers in this assay, from the lowest: compounds 2, 4, 1 and 3 (each within the scatter of the next).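

In this assay, going by these compounds alone, the nitro group gives the first reading of an electron-neutral-free comparison at this position only in name: the step is a number 1.1 percentage points lower from compound 1 to compound 4 (within the scatter) for adding it to the plain phenyl group, a number 1.3 percentage points higher from compound 2 to compound 4 (within the scatter) against 4-methoxyphenyl and a number 2.3 percentage points lower from compound 3 to compound 4 (within the scatter) against 4-(dimethylamino)phenyl.

Correct version, replacing the garbled sentence above:

In this assay the nitro group adds a new kind of substituent on the aromatic ring at this saturated ring carbon, and the step is a number 1.1 percentage points lower from compound 1 to compound 4 (within the scatter) against the plain phenyl group. The same holds against the two other substituted rings, with a number 1.3 percentage points higher from compound 2 to compound 4 (within the scatter) and a number 2.3 percentage points lower from compound 3 to compound 4 (within the scatter), so 3-nitrophenyl does not separate itself from 4-methoxyphenyl or 4-(dimethylamino)phenyl, and all four compounds remain unordered. Nothing available accounts for this flat picture.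

On these data alone, whether any group on this aromatic ring can move the number beyond the scatter stays open, for instance a carboxylic acid or a hydroxyl. Also open, as far as these compounds go, is whether the phenyl group on the ring nitrogen matters, as it stays the same in all four compounds.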